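The source may report more compounds than this note shows. Statements on the series, on what has been measured and on what is new or still open speak of the compounds shown alone.

In a functional assay on L1210 cells (Mus musculus) for inhibition (on this read-out higher numbers stand for weaker inhibition and lower numbers for stronger inhibition), compound 3 (`C#Cc1c(C#N)ncn1C1O[C@H](CO)[C@@H](O)[C@H]1O`) gives 1.9 ug/mL. Compound 1 (`CCCCC#Cc1c(C(N)=O)ncn1C1O[C@H](CO)[C@@H](O)[C@H]1O`) gives 2.29 ug/mL. Compound 2 (`NC(=O)c1ncn(C2O[C@H](CO)[C@@H](O)[C@H]2O)c1C#Cc1ccccc1`) gives 20.6 ug/mL. The gap between compound 3 and compound 1 lies within the scatter, and the gap between compound 3 and compound 2 lies beyond it. Compound 4 (`CCCC#Cc1c(C#N)ncn1C1O[C@H](CO)[C@@H](O)[C@H]1O`) carries propyl in place of hydrogen on a triple-bonded carbon. Among the compounds with values here, no measured step covers this exact change. The nearest is a 9.0-fold higher number from compound 1 to compound 2 (0.95 log units; beyond the scatter), which shows that the read-out can move with the group at such a carbon. Compound 1, bearing butyl there, stays at 2.29 ug/mL, although it also differs from compound 3 elsewhere. A modest move towards weaker inhibition is therefore expected, with an estimated 2.6-fold higher number from compound 3 to compound 4 (0.42 log units; beyond the scatter). Compound 4 is estimated at 5 ug/mL, within a range of 1.5 ug/mL to 20 ug/mL.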

Compound 4, half-maximal inhibitory concentration: 14.8 ug/mL
Beside the measured number, compound 4's estimate is 3.0-fold (0.47 log units) below it, and the stated range covers the measured number.
By their numbers in this assay, from the lowest: compounds 3 and 1 (each within the scatter of the next); then compounds 4 and 2 (each within the scatter of the next).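

In this assay propyl in place of hydrogen on a triple-bonded carbon gives a 7.8-fold higher number from compound 3 to compound 4 (0.89 log units; beyond the scatter) and so moves the read-out towards weaker inhibition. This is the first step shown that starts from the unsubstituted ethynyl group, and it shows that with the nitrile kept in place, adding a chain at this carbon is enough to weaken inhibition beyond the scatter. No measurement at hand explains this shift. The compounds shown leave open how a shorter group such as methyl would read at this carbon. They also leave open whether a hydroxyl or an amine at the end of the propyl chain would change the result.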